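Halogen for Nitro on the Quinolinone-Benzimidazole Core

The source may hold more compounds than are shown below. What is called first, only, known or untested is meant among the compounds shown, and "the series" means these compounds.

Compound 1 `Cc1ccc2[nH]c(=O)c(-c3nc4cc([N+](=O)[O-])ccc4[nH]3)cc2c1`: in a functional assay on SK-OV-3 cells (Homo sapiens) for cytotoxicity, read by MTT assay, with a stated time of 48 h (on this read-out higher numbers stand for weaker inhibition and lower numbers for stronger inhibition), compound 1 gives > 100000 nM, a limit of the assay.
Compound 2 `O=c1[nH]c2ccccc2cc1-c1nc2cc(Br)ccc2[nH]1`: compound 2 gives 11400 nM.
Compound 3 `O=c1[nH]c2ccccc2cc1-c1nc2cc([N+](=O)[O-])ccc2[nH]1`: compound 3 gives > 100000 nM, again a limit.

Compound 1 stands only at a limit, so no number is known for it; the step that the two limits leave unreadable from compound 1 to compound 3 from the methyl to hydrogen change is likewise unreadable, and the limit of > 100000 nM in this assay, at which 2 of the 3 values shown sit, marks where both of these values sit. Compound 4 `Cc1ccc2[nH]c(=O)c(-c3nc4cc(Cl)ccc4[nH]3)cc2c1` differs from compound 1 by chloro in place of nitro on an aromatic carbon. Within the data shown here, the one step that bears on this is an at least 8.7-fold higher number from compound 2 to compound 3 (0.94 log units; beyond the scatter), which runs from a halogen to nitro and is at least modest; the change to compound 4 runs the other way, from nitro to a halogen, with chloro rather than bromo. A lower number for compound 4 than for compound 1 is therefore expected, a step of about an at least 6.6-fold lower number from compound 1 to compound 4 (0.82 log units; beyond the scatter), with the value of compound 2 as the nearest guide. Compound 4 is estimated at 15000 nM, with a range from 5000 nM to 60000 nM.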

Compound 4, half-maximal inhibitory concentration: 33000 nM
The estimate for compound 4 lay 2.2-fold (0.34 log units) below the measured number; the range from low to high includes it.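

In this assay, the change from nitro to chloro gives an at least 3.0-fold lower number from compound 1 to compound 4 (0.48 log units; beyond the scatter). Among these compounds, the only readable step before this ran between bromo and nitro on the core without the methyl, so the lower number on leaving nitro for a halogen now also appears with the methyl present, and with chloro as well as bromo. This step is a bound and not a size, because compound 1 stands at a limit: the limit of > 100000 nM in this assay, at which 2 of the 4 values shown sit.

As far as these compounds go, the step from compound 1 to compound 3 cannot be read, so what the methyl contributes on this core remains open. Also open, from the compounds shown here alone, are whether chloro and bromo differ on one and the same core, and how an amine, a carboxylic acid or a fluoro at this position would compare with chloro.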